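This account rests on a few compounds, and the source may have more. Where it says the series, first, only, none or still open, it means among the compounds named here.

In an ADME assay on Vero cells (Chlorocebus sabaeus) for cytotoxicity, read by MTT assay, with a stated time of 72 h (a higher number here means that more compound is needed for the effect, a lower number that less compound is needed), two compounds that share one core have been measured so far. Compound 1 (`COc1ccccc1C(=O)Nc1nc(-c2ccccn2)cs1`) gives 43500 nM. Compound 2 (`O=C(Nc1nc(-c2ccccn2)cs1)c1ccc(Br)cc1`) gives 4700 nM, the lower of the two numbers, and the gap between them lies beyond the usual scatter. Compound 3 (`O=C(Nc1nc(-c2ccccn2)cs1)c1ccccc1Cl`) has not yet been measured. It differs from compound 2 in one place, on a carbonyl carbon, with 2-chlorophenyl in place of 4-bromophenyl (2-chlorophenyl in place of 4-bromophenyl on a carbonyl carbon). For the measured compounds named here, no step of this kind has been measured, so the expectation leans only on the two known numbers, compound 2 at 4700 nM and compound 1 at 43500 nM. A moderate rise, a little beyond the scatter, is expected, and the estimated step is a 3.0-fold higher number from compound 2 to compound 3 (0.47 log units; beyond the scatter) in this assay. Compound 3 is estimated at 14000 nM, with an expected range from 4000 nM to 50000 nM.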

Compound 3, half-maximal effective concentration: 2000 nM
Compound 3: middle estimate off by 7.0-fold (0.85 log units), on the high side; the measured number lies below the stated range.
By their numbers in this assay, from the lowest: compound 3; then compound 2; then compound 1.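

In this assay, placing 2-chlorophenyl in place of 4-bromophenyl on a carbonyl carbon gives a 2.4-fold lower number from compound 2 to compound 3 (0.37 log units; beyond the scatter), which makes compound 3 the compound needing the least of the three to produce the effect. Chloro in place of methoxy on an aromatic carbon gives a 22-fold lower number from compound 1 to compound 3 (1.34 log units; beyond the scatter), a large shift from exchanging a single group on the aromatic ring. No supporting measurement gives a reason for either step.

Because the step from 4-bromophenyl to 2-chlorophenyl changes both the halogen and where it sits, these compounds cannot separate the two contributions; 4-chlorophenyl or 2-bromophenyl would be needed to do so. As far as these compounds go, how an amine or a carboxylic acid on this ring would compare also remains open.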